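The source may hold more compounds than are shown below. What is called first, only, known or untested is meant among the compounds shown, and "the series" means these compounds.

Working notes on the series.

Compound 1 `COc1ccc(Cn2c3c(c4ccccc4c2=O)CCOc2ccccc2-3)cc1` and compound 2 `COc1ccc(Cn2c3c(c4ccc(C)cc4c2=O)CCOc2ccccc2-3)cc1` share one core; compound 3 `COCOc1ccccc1-c1cc2ccccc2c(=O)n1C` and compound 4 `COCOc1ccccc1-c1cc2cc(C)ccc2c(=O)n1C` share another. The difference between the two cores is not broken down here.

In a functional assay on HeLa cells (Homo sapiens) for cytotoxicity, read by sulforhodamine B assay (on this read-out higher numbers stand for weaker inhibition and lower numbers for stronger inhibition), compound 1 gives 4780 nM. In this assay compound 2 gives 4540 nM. The change between them is methyl in place of hydrogen on an aromatic carbon and the step it made is a 1.1-fold lower number from compound 1 to compound 2 (0.02 log units; within the scatter). In this assay compound 3 gives 64600 nM, which is the highest of the three numbers and stands beyond the scatter from both compound 1 and compound 2.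

The change from compound 3 to compound 4 is methyl in place of hydrogen on an aromatic carbon. For the measured compounds named here, it is the same kind of change as the one from compound 1 to compound 2, not the same: in compound 3 the aromatic carbon sits in a fused or bridged system of two rings, where in compound 1 it sits in a fused or bridged system of four rings. The change occurs twice among the compounds shown and the only measured instance of it stayed within the scatter.

On that single instance, the expectation for compound 4 in this assay is a step of about a 1.1-fold lower number from compound 3 to compound 4 (0.03 log units; within the scatter), resting on the step of a 1.1-fold lower number from compound 1 to compound 2 (0.02 log units; within the scatter), so compound 4 is expected to give roughly 60000 nM, estimated between 26000 nM and 150000 nM.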

Compound 4, half-maximal inhibitory concentration: 28600 nM
Beside the measured number, compound 4's estimate is 2.1-fold (0.32 log units) above it; the measured number falls inside the stated range.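

In this assay, methyl in place of hydrogen on an aromatic carbon gives a 2.3-fold lower number from compound 3 to compound 4 (0.35 log units; beyond the scatter), a modest step on the core of compound 3. Set beside the earlier step on the core of compound 1, the two cannot be told apart: the same change on two cores in this assay, a 1.1-fold lower number (0.02 log units; within the scatter) from compound 1 to compound 2 and a 2.3-fold lower number (0.35 log units; beyond the scatter) from compound 3 to compound 4, 2.1-fold (0.33 log units) apart, within the scatter of two such steps. This gives no sign that the core alters the step, yet with one pair per core it does not show that the change carries over unaltered, and the fact that only the second step lies beyond the scatter is no evidence that the core matters.

The compounds shown leave open whether an ethyl, a chlorine, an amine or a carboxylic acid in place of this methyl would give a step of similar size on either core. They also leave open whether methyl on an aromatic carbon would give a comparable step on a third core, or at another place on these two.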